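The source may hold more compounds than are shown below. What is called first, only, known or untested is meant among the compounds shown, and "the series" means these compounds.

Series notes, step from compound 3 to compound 4.

The three measured compounds share one core. Compound 1 `c1cc(-c2nccs2)c2c(c1)C(c1ncc[nH]1)CC2` carries a 1,3-thiazol-2-yl group on the aromatic carbon and in a functional assay on CHO cells for agonist activity at Alpha-1A adrenergic receptor (Homo sapiens), read by FLIPR and calcium flux (a lower number here means that less compound is needed, a higher number that more compound is needed for the effect), compound 1 gives 426 nM. Compound 2 `CCS(=O)(=O)Nc1cccc2c1CCC2c1ncc[nH]1` carries an (ethylsulfonyl)amino group there, and in this assay compound 2 gives 32 nM. Compound 3 `Cc1n[nH]cc1-c1cccc2c1CCC2c1ncc[nH]1` carries a 3-methyl-1H-pyrazol-4-yl group, and in this assay compound 3 gives 3 nM. Compound 3 stands lowest of the three: the nearest is compound 2, and the steps are an 11-fold lower number from compound 2 to compound 3 (1.03 log units; beyond the scatter) and a 140-fold lower number from compound 1 to compound 3 (2.15 log units; beyond the scatter), while a 13-fold lower number from compound 1 to compound 2 (1.12 log units; beyond the scatter) separates the other two.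

Compound 4 `c1cc(-c2ccn[nH]2)c2c(c1)C(c1ncc[nH]1)CC2` differs from compound 3 in one place: 1H-pyrazol-5-yl in place of 3-methyl-1H-pyrazol-4-yl on an aromatic carbon. Every measured step in this assay changes the group on that same aromatic carbon, and each was large, so the position is sensitive. Among the compounds with values here, no measured step exchanges one pyrazolyl group for another, so the size of this step is not directly anchored. The entering group keeps the same ring, donor and acceptor count, and the change is expected to cost some potency while staying far from compound 1, giving a 3.0-fold higher number from compound 3 to compound 4 (0.48 log units; beyond the scatter) as the expected step.

Compound 4 is estimated at 9 nM in this assay, with a range from 2 nM to 45 nM.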

Compound 4, half-maximal effective concentration: 52 nM
The estimate for compound 4 lay 5.8-fold (0.76 log units) below the measured number; the whole stated range lies below it.
By their numbers in this assay, from the lowest: compound 3; then compounds 2 and 4 (each within the scatter of the next); then compound 1.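

In this assay, an exchange of one pyrazolyl group for another gives a 17-fold higher number from compound 3 to compound 4 (1.24 log units; beyond the scatter) and so matches the steps between unlike groups in size, although both groups count as one five-membered aromatic ring with 2 hetero atoms, 1 hydrogen-bond donor and 1 hydrogen-bond acceptor. These counts therefore do not fix the number at this aromatic carbon, and a pyrazolyl group as such does not carry the level of compound 3. The step of a 1.6-fold higher number from compound 2 to compound 4 (0.21 log units; within the scatter) lies within the scatter, so the 1H-pyrazol-5-yl and (ethylsulfonyl)amino groups cannot be told apart here, whereas an 8.2-fold lower number from compound 1 to compound 4 (0.91 log units; beyond the scatter) is modest but still separates the 1H-pyrazol-5-yl group from the 1,3-thiazol-2-yl group.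

This one step removes the methyl group and moves the point of ring attachment together, so the compounds shown cannot divide it between the two changes; the unsubstituted 1H-pyrazol-4-yl group would separate them. The data offer no explanation for the size of this step.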